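The source may report more compounds than this note shows. Statements on the series, on what has been measured and on what is new or still open speak of the compounds shown alone.

Measured compounds:
Compound 1 `ClCc1ccc(Cn2cnc3nc(Cl)nc(Cl)c32)cc1`: in a functional assay on BT-549 cells (Homo sapiens) for cytotoxicity, read by sulforhodamine B assay, with a stated time of 48 h (a lower number here means a stronger inhibitor of growth, a higher number a weaker inhibitor of growth), compound 1 gives 1860 nM.
Compound 2 `ClCc1ccccc1Cn1cnc2nc(Cl)nc(Cl)c21`: in this assay compound 2 gives 1340 nM.

Compound 1 has the highest of the two numbers recorded in this assay. Its nearest neighbour is compound 2, whose number is lower, but the gap between the two values lies within the scatter of this kind of measurement, so no order between compound 1 and compound 2 can be read from them.

Compound 3 `ClCc1ccc(Cn2cnc3ncnc(Cl)c32)cc1` has not yet been measured in this assay. It differs from compound 1 in one place: hydrogen in place of chloro on an aromatic carbon. The change sits on the shared core, on an aromatic carbon between two ring nitrogen atoms, leaving the other chloro group in place.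

Going by the values given here, no step between two measured compounds of this set involves the same change, so there is nothing here to calibrate the size of the step. The expectation for the step from compound 1 to compound 3 in this assay is therefore a small move towards a higher number, of the order of a 1.5-fold higher number from compound 1 to compound 3 (0.16 log units; within the scatter), a shift that could well stay within the scatter. Compound 3 is accordingly estimated at 2700 nM in this assay, with a likely range from 1000 nM to 7000 nM.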

Compound 3, concentration for 50% growth inhibition: 3710 nM
Estimate against measurement, compound 3: 1.4-fold (0.14 log units) below; the range from low to high includes it.
By their numbers in this assay, from the lowest: compounds 2, 1 and 3 (each within the scatter of the next, the first and the last beyond it).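

The step from chloro to hydrogen on this aromatic carbon, which lies between two ring nitrogen atoms, is a 2.0-fold higher number from compound 1 to compound 3 (0.30 log units; within the scatter) in this assay. Going by these compounds alone, the earlier compounds differed only in their chloromethyl-bearing part, so this is the first reading of a change on the shared core, and it shows that removing this chloro group does not move the number beyond the scatter, although the step reaches the edge of it. With the other chloro group still in place, this single step cannot say whether the chloro group at this position contributes to growth inhibition, and no measurement shown here bears on what lies behind the step.

What the compounds leave open is how an amine, a methoxy group or a methyl group on this same aromatic carbon would read in this assay, as only chloro and hydrogen are shown there. Also open, as far as these compounds go, are whether the same change gives a similar step on the scaffold of compound 2, and what replacing the remaining chloro group or the chloromethyl group with hydrogen would do.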